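A few compounds are considered here, and "the series" means these few. Any claim that something is new, unique, unknown or untested is made for them only; others in the source may bear on it.

Compound 1 `CCCCCCCCCCCCNC(=O)[C@@H](NC(=O)c1ccco1)[C@@H](C)O` and compound 2 `CCCCCCCCCCCCCCNC(=O)[C@@H](NC(=O)c1ccco1)[C@@H](C)O` share the same core and differ only in the length of the saturated chain. In a functional assay on SiHa cells (Homo sapiens) for cytotoxicity, read by MTT assay, with a stated time of 48 h (a higher number here means a weaker inhibitor, a lower number a stronger inhibitor), compound 1 gives 64300 nM, and compound 2 gives 127000 nM. Within the data shown here, the one measured step, a 2.0-fold higher number from compound 1 to compound 2 (0.30 log units; within the scatter), is a lengthening of the chain. Among the measured compounds shown here, compound 2 thus stands at the higher of the two numbers, with compound 1 its only neighbour and the gap between them within the scatter. Compound 3 `CCCCCCCCCCCCCCNC(=O)[C@@H](NC(=O)/C=C/c1ccccc1)[C@@H](C)O` keeps the chain of compound 2 and changes the acyl part: 2-phenylethenyl in place of furan-2-yl on a carbonyl carbon. For the measured compounds named here, no measured step touches this part of the molecule, so the chain step of compound 1 to compound 2 offers no direct guide, and both measured numbers sit in the same weak region. For compound 3 in this assay a step of a 1.3-fold lower number from compound 2 to compound 3 (0.10 log units; within the scatter) is expected, no change beyond the scatter. The estimate for compound 3 is 100000 nM, within 30000 nM to 300000 nM.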

Compound 3, half-maximal inhibitory concentration: 35800 nM
The estimate for compound 3 lay 2.8-fold (0.45 log units) above the measured number; low and high end bracket the measured number.
By their numbers in this assay, from the lowest: compounds 3, 1 and 2 (each within the scatter of the next, the first and the last beyond it).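

Among these compounds, the carbonyl carbon bearing the acyl group is the first place where a single change moves the number beyond the scatter. In this assay, 2-phenylethenyl in place of furan-2-yl gives a 3.5-fold lower number from compound 2 to compound 3 (0.55 log units; beyond the scatter), while the lengthening of the chain gave only a 2.0-fold higher number from compound 1 to compound 2 (0.30 log units; within the scatter). Nothing at hand explains this modest shift, which swaps 5 heavy atoms with 1 hydrogen-bond acceptor for 8 carbon atoms with a double bond outside the ring and no acceptor.

Going by these compounds, whether the shift belongs to the double bond or to the six-membered ring stays open, a question that a 2-phenylethyl or a plain phenyl group on that carbonyl carbon could settle. Also open, on these data alone, is how 2-phenylethenyl reads on the shorter chain of compound 1, and how an amine or a carboxylic acid on its phenyl ring would read.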